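The source may hold more compounds than are shown below. What is called first, only, known or untested is meant among the compounds shown, and "the series" means these compounds.

Working notes on the cytotoxicity series. Compound 1, `Cc1cc(NC(=O)Nc2ncccc2C)c2ccccc2n1`, was tested in an ADME assay on HEK293 cells (Homo sapiens) for cytotoxicity, with a stated time of 72 h; a higher number here means that more compound is needed for the effect, a lower number that less compound is needed. In this assay compound 1 gives only a limit, > 25000 nM, and no number. Compound 2, `Cc1cc(NC(=O)Nc2ccccc2C(F)(F)F)c2ccccc2n1`, shares the core of compound 1 and carries a trifluoromethyl group in place of the methyl on the pyridine. In this assay compound 2 likewise returns only a limit, > 25000 nM. Both values shown thus lie at the limit of > 25000 nM in this assay, at which 2 of the 2 values shown sit, so compound 1 stands at the edge of the measured window and cannot be ranked against compound 2.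

Compound 3, `Cc1cc(NC(=O)Nc2ccc(O)cc2)c2ccccc2n1`, is the next member. It differs from compound 1 in one place: 4-hydroxyphenyl in place of 3-methylpyridin-2-yl on an amide-type nitrogen. The 3-methylpyridin-2-yl group leaves and a 4-hydroxyphenyl group enters on the amide-type nitrogen whose other neighbour is the carbonyl carbon.

Among the compounds with values here, no step between measured compounds exists to anchor the size of this change. The expected step is a step that the limit leaves unreadable from compound 1 to compound 3, none beyond the usual scatter in either direction. Compound 3 is expected to give about 30000 nM in this assay, within the range 12000 nM to 80000 nM, most likely reported again as a limit.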

Compound 3, half-maximal effective concentration: > 25000 nM
Compound 3 was reported as a limit; the forecaster's own chance of this, stated with the estimate: 75%; the middle value lies beyond the limit too.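

Within the data shown here, no step from compound 1 to compound 3 can be read, since both are reported only as limits in this assay: the limit of > 25000 nM in this assay, at which 3 of the 3 values shown sit. The compounds shown leave open at what concentration, if any, members of this series act in this assay, and whether 4-hydroxyphenyl in place of 3-methylpyridin-2-yl changes that concentration.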